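The compounds below may be only part of what the source reports. "The series", "measured", "known", "first", "only" and "open" are said of these compounds alone.

Two compounds share one core and differ only in the group on the outer phenyl ring. In a functional assay on PC-3 cells (Homo sapiens) for inhibition, read by sulforhodamine B assay, with a stated time of 48 h, tested at 10 uM (on this read-out higher numbers stand for more inhibition at the one concentration tested (going by the name of the read-out) and lower numbers for less inhibition), compound 1 `c1ccc(-c2cn3ccnc3c(-c3ccc4ncn(C5CCCCC5)c4c3)n2)cc1` gives 92%, while compound 2 `O=Cc1ccc(-c2cn3ccnc3c(-c3ccc4ncn(C5CCCCC5)c4c3)n2)cc1`, which carries a formyl group on that ring, gives 19%. Among the measured compounds shown here, compound 2 therefore stands lowest of the two numbers measured, and the one measured step, a number 73 percentage points lower from compound 1 to compound 2 (beyond the scatter), is the only guide available.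

Compound 3 `Clc1ccc(-c2cn3ccnc3c(-c3ccc4ncn(C5CCCCC5)c4c3)n2)cc1` is not yet measured. It differs from compound 2 as follows: chloro in place of formyl on an aromatic carbon. For the measured compounds named here, no measured pair swaps formyl for chloro, so the step from compound 2 to compound 3 has no direct precedent. Going by these compounds, the measured step shows that adding formyl cost a great deal, so taking it away is expected to recover part of that loss, but how far a chloro group stands from hydrogen is unknown here. The expected step is a number 41 percentage points higher from compound 2 to compound 3 (beyond the scatter), an increase. Compound 3 is estimated at 60%, between 25% and 95%.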

Compound 3, a percentage reported as inhibition, at one concentration (the size of the read-out at that concentration, not a potency): 24.6%
Beside the measured number, compound 3's estimate is 35.4 percentage points above it, and the stated range ends above it.
By their numbers in this assay, from the lowest: compounds 2 and 3 (each within the scatter of the next); then compound 1.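

In this assay, replacing formyl with chloro on this aromatic carbon, para to a large group, gives a number 5.6 percentage points higher from compound 2 to compound 3 (within the scatter), so the two groups cannot be told apart in this read-out. Set against the unsubstituted ring, chloro gives a number 67.4 percentage points lower from compound 1 to compound 3 (beyond the scatter), which shows that the large loss seen earlier is not confined to formyl: it also appears with a single chlorine atom, which has no double bond and no hydrogen-bond acceptor. No supporting data bear on why either group goes with so much less inhibition than hydrogen.

Going by these compounds, it remains open whether every group at this position behaves in this way, or whether a small fluoro, a methoxy, an amine or a carboxylic acid would keep the inhibition of compound 1. On these data alone, the effect of chloro elsewhere on this ring also remains open.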